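Ortho nitro for methyl on a benzofuran sulfonamide series

The source may report more compounds than this note shows. Statements on the series, on what has been measured and on what is new or still open speak of the compounds shown alone.

The measured compounds and their values:
compound 1, `CCOC(=O)c1oc2ccc(NS(=O)(=O)c3cccc(C)c3)cc2c1C`: 29500 nM
compound 2, `CCOC(=O)c1oc2ccc(NS(=O)(=O)c3ccccc3C)cc2c1C`: 89200 nM
compound 3, `CCOC(=O)c1oc2ccc(NS(=O)(=O)c3ccccc3Cl)cc2c1C`: > 200000 nM (a limit of the assay)

The three share a core and differ only in the aryl group on the sulfonyl sulfur. In a functional assay on MDA-MB-231 cells (Homo sapiens) for antiproliferative activity, read by MTT assay, with a stated time of 72 h (a higher number here means a weaker inhibitor, a lower number a stronger inhibitor), compound 1 gives 29500 nM. Compound 2 gives 89200 nM in this assay, which is the highest of the two plain numbers. The value of compound 3 in this assay is a limit and not a number, as shown by the limit of > 200000 nM in this assay, at which 1 of the 3 values shown sits. The step of a 3.0-fold higher number from compound 1 to compound 2 (0.48 log units; beyond the scatter) is modest, and an at least 6.7-fold higher number from compound 1 to compound 3 (0.83 log units; beyond the scatter) is at least modest. Most directly relevant is an at least 2.2-fold higher number from compound 2 to compound 3 (0.35 log units; beyond the scatter), where chloro replaces methyl on the aromatic carbon.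

Compound 4, `CCOC(=O)c1oc2ccc(NS(=O)(=O)c3ccccc3[N+](=O)[O-])cc2c1C`, is not yet measured. It differs from compound 2 by nitro in place of methyl on an aromatic carbon. Within the data shown here, the one measured step that changes the group at that same aromatic carbon, an at least 2.2-fold higher number from compound 2 to compound 3 (0.35 log units; beyond the scatter), raised the number at least modestly and pushed the value to the limit. The expectation for compound 4 is therefore a weaker inhibitor than compound 2, with a fair chance that only a limit is returned. Compound 4 is expected to give about 200000 nM in this assay, within 80000 nM to 500000 nM. This corresponds to an expected step of a 2.2-fold higher number from compound 2 to compound 4 (0.35 log units; beyond the scatter).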

Compound 4, half-maximal inhibitory concentration: 80400 nM
Estimate against measurement, compound 4: 2.5-fold (0.40 log units) above; the range from low to high includes it.
By their numbers in this assay, from the lowest: compound 1; then compounds 4 and 2 (each within the scatter of the next). At a limit, above all of these: compound 3.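

With 2-nitrophenyl in place of 2-methylphenyl on the sulfonyl sulfur, the two values in this assay cannot be told apart, a 1.1-fold lower number from compound 2 to compound 4 (0.05 log units; within the scatter), so this aromatic carbon, ortho to a large group, accepts nitro as well as methyl in this assay, a result that the step from methyl to chloro alone could not have shown. The outcome at this carbon therefore depends on which group enters, since nitro in place of chloro gives an at least 2.4-fold lower number from compound 3 to compound 4 (0.39 log units; beyond the scatter), while the 2-nitrophenyl group still falls short of the 3-methylphenyl group, a 2.7-fold higher number from compound 1 to compound 4 (0.44 log units; beyond the scatter). The value of compound 3 is a limit of the assay and not a number: the limit of > 200000 nM in this assay, at which 1 of the 4 values shown sits.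

What the compounds shown leave open is whether an amine or a carboxylic acid on this same carbon would give a value in line with compound 2 and compound 4, or a limit as with compound 3. Also open, going by these compounds, is whether nitro on the carbon that carries methyl in compound 1 would keep the value of that compound.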